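A few compounds are considered here, and "the series" means these few. Any claim that something is new, unique, unknown or untested is made for them only; others in the source may bear on it.

Measured compounds in this series:

compound 1, `CN1C(=O)CC[C@@H](NC(=O)OCc2ccccc2)C1=O`: 47.5 mg/kg
compound 2, `O=C1CC[C@H](NC(=O)OCc2ccccc2)C(=O)N1`: 43.1 mg/kg
compound 3, `O=C1C[C@@H](NC(=O)OCc2ccccc2)C(=O)N1`: 125 mg/kg

All three were run in a functional assay on the whole organism with Mus musculus as the target; a higher number here means that more compound is needed for the effect, a lower number that less compound is needed. Compound 3 gives the highest number of the three, 125 mg/kg; the nearest is compound 1 with 47.5 mg/kg, and compound 2 with 43.1 mg/kg is the furthest, both gaps lying beyond the usual scatter.

The next compound is compound 4, `CN1C(=O)C[C@@H](NC(=O)OCc2ccccc2)C1=O`, which has not yet been measured in this assay. Its difference from compound 3 is methyl in place of hydrogen on an amide-type nitrogen in a ring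

No step between two measured compounds is shown for this change. The two values of compound 1 and compound 2 lie within the scatter of each other, and that is all those two compounds show. On that basis the step from compound 3 to compound 4 is expected to be small, with no direction beyond the scatter; the expected step is a 1.1-fold lower number from compound 3 to compound 4 (0.04 log units; within the scatter). Compound 4 is estimated at 115 mg/kg in this assay, within a range of 60 mg/kg to 230 mg/kg.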

Compound 4, dose for half-maximal effect: 52.5 mg/kg
For compound 4 the middle estimate is 2.2-fold (0.34 log units) above the measured one; measured number outside the range, below it.
By their numbers in this assay, from the lowest: compounds 2, 1 and 4 (each within the scatter of the next); then compound 3.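

In this assay, methyl in place of hydrogen on an amide-type nitrogen in a ring gives the first readable single-change result in this series, with a 2.4-fold lower number from compound 3 to compound 4 (0.38 log units; beyond the scatter) for this change. This shows that the nitrogen of the five-membered non-aromatic ring does not tolerate substitution neutrally in this assay: a single added carbon is enough to shift the number beyond the scatter, and in the favourable direction. No supporting measurement bears on why the number moves.

On these data alone, whether the step is specific to methyl remains open, as an ethyl group, a longer chain or a benzyl group on the same nitrogen would show whether it persists, grows or reverses. The compounds shown also leave open whether an amine or a carboxylic acid on that nitrogen would be accepted.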